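The compounds below may be only part of what the source reports. "The series", "measured", "known", "first", "only" and "open" are said of these compounds alone.

Compound 2 `CCCCN(c1nc2c(C(=O)O)cccc2o1)[C@H](C)c1ccc(-c2cc(Cl)ccc2-c2nc(=O)o[nH]2)cc1` gives 1040 ng.h/mL in an ADME assay on the whole organism (Macaca fascicularis) for pharmacokinetics, read by LC-MS, using cassette dosing, at a dose of 1 mg/kg by the oral route (a higher number here means more compound in the circulation at the dose given, a lower number less compound in the circulation), a number that sits within the scatter of compound 1 `C[C@H](c1ccc(-c2cc(Cl)ccc2-c2nc(=O)o[nH]2)cc1)N(CC1CC1)c1nc2c(C(=O)O)cccc2o1`, which gives 1300 ng.h/mL. Going by the values given here, the only measured step, a 1.3-fold lower number from compound 1 to compound 2 (0.10 log units; within the scatter), changed a chain and says nothing direct about a halogen swap. Compound 3 `CCCCN(c1nc2c(C(=O)O)cccc2o1)[C@H](C)c1ccc(-c2cc(F)ccc2-c2nc(=O)o[nH]2)cc1` differs from compound 2 by fluoro in place of chloro on an aromatic carbon. Among the compounds with values here, with no measured step bearing on this change, the expectation is a step no larger than the scatter, so compound 3 is estimated at 1000 ng.h/mL, with a range from 400 ng.h/mL to 2500 ng.h/mL. The expected step is a 1.0-fold lower number from compound 2 to compound 3 (0.02 log units; within the scatter).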

Compound 3, area under the concentration-time curve: 1630 ng.h/mL
For compound 3 the middle estimate is 1.6-fold (0.21 log units) below the measured one; measured number inside the range.
By their numbers in this assay, from the lowest: compounds 2, 1 and 3 (each within the scatter of the next).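

At this aromatic carbon, meta to a large group and para to a group of 6 heavy atoms, fluoro in place of chloro gives a 1.6-fold higher number from compound 2 to compound 3 (0.20 log units; within the scatter) in this assay for this pair. The two halogens therefore cannot be told apart here, something the earlier chain step could not show. Nothing measured bears on the reason for this result.

From the compounds shown here alone, whether a nitrile, a methoxy or an amine on this carbon would move the number beyond the scatter remains open. So does whether fluoro reads the same alongside the cyclopropyl group of compound 1.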